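Swapping the Dialkylamino Group on the Shared Core

The source may hold more compounds than are shown below. What is called first, only, known or untested is meant among the compounds shown, and "the series" means these compounds.

compound 1: `CCCCN(CC#N)c1nc(C)nc(N(CC)c2ccc(N(C)C)cc2C(F)(F)F)n1` — 6 nM
compound 2: `CCCN(CCC)c1nc(C)nc(N(CC)c2ccc(N(C)C)cc2C)n1` — 7 nM

Of the compounds shown here, two have been measured in an assay on isolated protein for binding affinity to corticotropin-releasing factor receptor 1 (Homo sapiens); on this read-out higher numbers stand for weaker inhibition and lower numbers for stronger inhibition. Compound 1 `CCCCN(CC#N)c1nc(C)nc(N(CC)c2ccc(N(C)C)cc2C(F)(F)F)n1` gives 6 nM, and compound 2 `CCCN(CCC)c1nc(C)nc(N(CC)c2ccc(N(C)C)cc2C)n1` gives 7 nM. Compound 2 thus carries the higher of the two numbers, but its gap to compound 1 lies within the scatter, so the two cannot be told apart on this read-out.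

Compound 3 `CCCCN(CC#N)c1nc(C)nc(N(CC)c2ccc(N(C)C)cc2C)n1` has not yet been measured. It differs from compound 2 in one place: butyl(cyanomethyl)amino in place of dipropylamino on an aromatic carbon. Among the compounds with values here, compound 1 already bears the butyl(cyanomethyl)amino group, though its partner differs elsewhere, so no clean step for this change alone has been measured. Because compound 1 gives 6 nM and compound 2 gives 7 nM, a step from compound 2 to compound 3 is expected to be small in this assay, if any, and not beyond the scatter. The expected step is a 1.2-fold lower number from compound 2 to compound 3 (0.07 log units; within the scatter). For compound 3 the inhibition constant is estimated at 6 nM, with a range from 2.5 nM to 15 nM.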

Compound 3, inhibition constant: 8 nM
For compound 3 the middle estimate is 1.3-fold (0.12 log units) below the measured one; the measured number falls inside the stated range.
By their numbers in this assay, from the lowest: compounds 1, 2 and 3 (each within the scatter of the next).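

In this assay, within the data shown here, butyl(cyanomethyl)amino in place of dipropylamino on an aromatic carbon gives a 1.1-fold higher number from compound 2 to compound 3 (0.06 log units; within the scatter), the first clean reading of this swap, and on this read-out the two amino groups cannot be told apart. Methyl in place of trifluoromethyl, a change the earlier pair could not isolate, gives a 1.3-fold higher number from compound 1 to compound 3 (0.12 log units; within the scatter), so these two groups cannot be told apart here either. No independent measurement bears on why both changes stay within the scatter.

The compounds shown leave open whether a longer chain, as in dibutylamino, or an ether-bearing group such as bis(2-methoxyethyl)amino would move the number beyond the scatter at the dialkylamino position. They also leave open whether chlorine or methoxy in place of the methyl group would do so.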